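Dropping the methoxy group from a chalcone-type thiazole

A few compounds are considered here, and "the series" means these few. Any claim that something is new, unique, unknown or untested is made for them only; others in the source may bear on it.

Measured compounds:
- Compound 1, `Cc1nc(Nc2ccc(Cl)cc2)sc1C(=O)/C=C/c1ccccc1`: > 25000 nM
- Compound 2, `COc1cccc(/C=C/C(=O)c2sc(Nc3ccc(C)cc3)nc2C)c1`: > 25000 nM

Of the compounds shown here, two have been tested in a functional assay on NCI-H460 cells (Homo sapiens) for cytotoxicity, read by MTT assay; on this read-out higher numbers stand for weaker inhibition and lower numbers for stronger inhibition. Compound 1 gives > 25000 nM, which is a limit of the assay rather than a number. Compound 2 gives > 25000 nM, likewise a limit and not a number. Compound 2 therefore stands at the same limit as the other value shown, and nothing places it above or below compound 1; both sit at the limit of > 25000 nM in this assay, at which 2 of the 2 values shown sit.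

Compound 3, `Cc1ccc(Nc2nc(C)c(C(=O)/C=C/c3ccccc3)s2)cc1`, is yet to be tested in this assay. It differs from compound 2 by hydrogen in place of methoxy on an aromatic carbon. Among the compounds with values here, no step between measured compounds is recorded, so the size of this change cannot be read from the data. Since compound 1, which also carries a plain phenyl on the enone, reaches only the limit, no movement beyond the scatter is expected for compound 3 and its result is most likely again a limit. For compound 3 the expected value in this assay is 30000 nM, with a range from 10000 nM to 100000 nM, which corresponds to an expected step that the limit leaves unreadable from compound 2 to compound 3.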

Compound 3, half-maximal inhibitory concentration: > 25000 nM
Compound 3: a limit, no number (the forecaster's own chance of this, stated with the estimate: 85%); the middle value lies beyond the limit too.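

In this assay compound 3 gives > 25000 nM, a limit and not a number. No step from compound 3 to compound 1 or compound 2 can be read, and all three stand together: the limit of > 25000 nM in this assay, at which 3 of the 3 values shown sit.

Going by these compounds, whether methoxy in place of hydrogen, or chloro in place of methyl, changes the result in this assay stays open.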